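Taking a methyl off compound 2

The compounds below may be only part of what the source reports. "The series", "measured", "known", "first", "only" and "open" are said of these compounds alone.

Values so far in a functional assay on LOX IMVI cells (Homo sapiens) for cytotoxicity, read by MTT assay, with a stated time of 24 h (a lower number here means a stronger inhibitor, a higher number a weaker inhibitor), are these:
- compound 1 `COc1cc(-c2nc(-c3ccccc3)[nH]c2-c2ccnc(NCCCNS(=O)(=O)c3ccccc3)n2)ccc1Cl` gives 7470 nM
- compound 2 `COc1cc(-c2nc(-c3ccccc3)[nH]c2-c2ccnc(NCCCNS(=O)(=O)c3ccc(Cl)cc3)n2)ccc1Cl` gives 60900 nM
- compound 3 `COc1cc(-c2nc(-c3ccccc3)[nH]c2-c2ccnc(NCCCNS(=O)(=O)c3ccc(C)cc3)n2)ccc1Cl` gives 18600 nM

Compound 2 stands highest of the three at 60900 nM and so is the weakest inhibitor here. Compound 4 `O=S(=O)(NCCCNc1nccc(-c2[nH]c(-c3ccccc3)nc2-c2ccc(Cl)c(O)c2)n1)c1ccc(Cl)cc1` turns its methoxy into hydroxy. The difference is hydrogen in place of methyl on an oxygen on an aromatic ring in words, hydrogen in place of methyl on an oxygen on an aromatic ring. For the measured compounds named here, no measured step touches this group. The nearest evidence is chloro or methyl changes on an aromatic carbon: an 8.2-fold higher number from compound 1 to compound 2 (0.91 log units; beyond the scatter) and a 2.5-fold higher number from compound 1 to compound 3 (0.40 log units; beyond the scatter) and a 3.3-fold lower number from compound 2 to compound 3 (0.52 log units; beyond the scatter) were all modest. A modest step is therefore expected in this assay with uncertain direction, though a lower number seems likelier because compound 2 already sits at the top with 60900 nM as its value. The expected change is a 2.0-fold lower number from compound 2 to compound 4 (0.31 log units; beyond the scatter) as an estimate. For compound 4 the estimated value is 30000 nM within an expected range of 8000 nM to 100000 nM overall.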

Compound 4, half-maximal inhibitory concentration: 61300 nM
The estimate for compound 4 lay 2.0-fold (0.31 log units) below the measured number; low and high end bracket the measured number.
By their numbers in this assay, from the lowest: compound 1; then compound 3; then compounds 2 and 4 (each within the scatter of the next).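

Hydrogen in place of methyl on this oxygen gives a 1.0-fold higher number from compound 2 to compound 4 (0.00 log units; within the scatter) in this assay. The chloro and methyl steps on an aromatic carbon all lay beyond the scatter, whereas this first step at the oxygen does not, so methoxy and hydroxy cannot be told apart here, at least with the chloro-bearing sulfonamide ring of these two compounds. Nothing measured here bears on this result. Still open, going by these compounds, is whether a longer chain such as ethyl on this oxygen, or an amine in place of the hydroxy, would read differently. Also open, on these data alone, is whether the same step would stay within the scatter in the parent compound 1.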